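Cinnamate ester of an iridoid glycoside and a hydroxypyridyl analogue

The compounds below may be only part of what the source reports. "The series", "measured", "known", "first", "only" and "open" are said of these compounds alone.

Compound 1 `C[C@]1(O)C[C@@H](OC(=O)/C=C/c2ccccc2)[C@@H]2C=CO[C@@H](O[C@@H]3O[C@H](CO)[C@@H](O)[C@H](O)[C@H]3O)[C@@H]21`: > 10000 nM
Compound 2 `COc1cc(C(=O)O[C@@H]2C[C@](C)(O)[C@H]3[C@H](O[C@@H]4O[C@H](CO)[C@@H](O)[C@H](O)[C@H]4O)OC=C[C@H]32)ccc1O[C@@H]1O[C@H](CO)[C@@H](O)[C@H](O)[C@H]1O`: > 10000 nM
Compound 3 `COc1cc(C(=O)O[C@@H]2C[C@](C)(O)[C@H]3[C@H](O[C@@H]4O[C@H](CO)[C@@H](O)[C@H](O)[C@H]4O)OC=C[C@H]32)cc(OC)c1O[C@@H]1O[C@@H](C)[C@H](O)[C@@H](O)[C@H]1O`: > 10000 nM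

In a functional assay on A549 cells (Homo sapiens) for cytotoxicity, read by MTT assay, with a stated time of 4 days (a lower number here means a stronger inhibitor, a higher number a weaker inhibitor), compound 1 reaches only a limit of the assay, > 10000 nM. Compound 2 likewise sits at a limit. Compound 3 also sits at a limit, so that the limit of > 10000 nM in this assay, at which 3 of the 3 values shown sit, describes all three values shown. Going by the values given here, no step between two numbers is available, and compound 1 stands where every measured compound stands.

Compound 4 `C[C@]1(O)C[C@@H](OC(=O)CCc2cc(O)ccn2)[C@@H]2C=CO[C@@H](O[C@@H]3O[C@H](CO)[C@@H](O)[C@H](O)[C@H]3O)[C@@H]21` differs from compound 1 by 2-(4-hydroxypyridin-2-yl)ethyl in place of 2-phenylethenyl on a carbonyl carbon. Among the compounds with values here, with no measured step to go on, the shared limit of compound 1 is the only guide, and no shift beyond the scatter is expected in this assay. Compound 4 is therefore expected to give 20000 nM, within 5000 nM to 100000 nM, a step that the limit leaves unreadable from compound 1 to compound 4.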

Compound 4, half-maximal inhibitory concentration: > 10000 nM
Compound 4: only a limit was reported (the forecaster's own chance of this, stated with the estimate: 85%); the middle value is on the limit's open side.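

In this assay, going by these compounds alone, compound 1 and compound 4 both sit at a limit, so no step between them can be read. The compounds shown leave open whether any change on the carbonyl carbon yields a measurable value in this assay.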